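A few compounds are considered here, and "the series" means these few. Any claim that something is new, unique, unknown or untested is made for them only; others in the source may bear on it.

In an ADME assay on MDBK cells (Bos taurus) for cytotoxicity, read by MTT assay, with a stated time of 96 h (a lower number here means that less compound is tolerated, a higher number that more compound is tolerated), compound 2 `C/C(=N\NC(N)=O)c1ccc2c(c1)nc(-c1ccc(C(F)(F)F)cc1)n2C1CCCCC1` gives > 100000 nM, a limit and not a number, so it stands at the limit of > 100000 nM in this assay, at which 1 of the 3 values shown sits. Compound 1 `CC(=O)c1ccc2c(c1)nc(-c1ccc(C(F)(F)F)cc1)n2C1CCCCC1` gives 52000 nM, and compound 3 `COc1ccc(-c2nc3cc(/C(C)=N/NC(N)=O)ccc3n2C2CCCCC2)c(OC)c1` gives 36000 nM.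

Compound 4 `C/C(=N\NC(N)=S)c1ccc2c(c1)nc(-c1ccc(C(F)(F)F)cc1)n2C1CCCCC1` departs from compound 2 in one place: a group of 3 heavy atoms (1 carbon, 1 nitrogen, 1 sulfur; no ring) in place of a group of 3 heavy atoms (1 carbon, 1 nitrogen, 1 oxygen; no ring), on an amine nitrogen. Carbamoyl leaves, and a group of the same size with sulfur in place of oxygen enters on the amine nitrogen.

Neither measured step touches this group, so both bear on it only indirectly. Changing the group on the aromatic carbon gave an at least 1.9-fold higher number from compound 1 to compound 2 (0.28 log units; that floor lies within the scatter). Exchanging the aryl group gave an at least 2.7-fold lower number from compound 2 to compound 3 (0.44 log units; beyond the scatter), which shows that a single change can bring a number back under the limit in this series. Going by the values given here, no measured step shows what an exchange of oxygen for sulfur does here, so the size of the new step is poorly fixed.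

A modest move to a lower number is expected in this assay, and the estimated step is an at least 2.2-fold lower number from compound 2 to compound 4 (0.34 log units; beyond the scatter). That expectation leans on compound 3 at 36000 nM. A result at the limit remains possible.

For compound 4 the estimate is 45000 nM, with an expected range of 15000 nM to 100000 nM.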

Compound 4, half-maximal cytotoxic concentration: > 100000 nM
Compound 4: a limit, no number (the forecaster's own chance of this, stated with the estimate: 30%); middle value at least 2.2-fold (0.34 log units) from the limit.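

In this assay compound 4 gives > 100000 nM, a limit and not a number. Sulfur in place of oxygen on the amine nitrogen therefore does not bring the number under the limit, whereas the aryl exchange gave an at least 2.7-fold lower number from compound 2 to compound 3 (0.44 log units; beyond the scatter); the step between the two limit compounds cannot be read, and any real difference between them stays hidden: the limit of > 100000 nM in this assay, at which 2 of the 4 values shown sit. The sulfur-bearing side chain gives an at least 1.9-fold higher number from compound 1 to compound 4 (0.28 log units; that floor lies within the scatter), and the oxygen-bearing one gives an at least 1.9-fold higher number from compound 1 to compound 2 (0.28 log units; that floor lies within the scatter), so neither side chain is shown by these floors to raise the number beyond the scatter.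

Still open, on these data alone, is how sulfur in place of oxygen behaves with 2,4-dimethoxyphenyl in place of 4-(trifluoromethyl)phenyl, the one setting where the oxygen compound has a number under the limit, so that a step could be read. Also open, as far as these compounds go, is whether another group on the amine nitrogen, such as acetyl or a methyl-substituted carbamoyl, would stay at the limit or come under it.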